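Para-dimethylamino analogue of a pyridoimidazole thioacetamide

This account rests on a few compounds, and the source may have more. Where it says the series, first, only, none or still open, it means among the compounds named here.

Compound 2 `O=C(CSc1nc2cccnc2[nH]1)Nc1ccccc1` and compound 1 `O=C(CSc1nc2cccnc2[nH]1)Nc1cccc(Br)c1` share one core. In an assay on isolated protein for inhibition of Ectonucleotide pyrophosphatase/phosphodiesterase family member 1 (Homo sapiens), tested at 10 uM (on this read-out higher numbers stand for more inhibition at the one concentration tested (going by the name of the read-out) and lower numbers for less inhibition), compound 2 gives 30%, and compound 1 gives 23%; the step of a number 7 percentage points higher from compound 1 to compound 2 (within the scatter) shows the two sit within the scatter of each other. Compound 3 `CN(C)c1ccc(NC(=O)CSc2nc3cccnc3[nH]2)cc1` differs from compound 2 by dimethylamino in place of hydrogen on an aromatic carbon. Going by the values given here, no measured step tests this change; the only step known, hydrogen for bromo, moved the number little, so compound 3 is expected to stay near compound 2, with an expected step of no change at the digits printed from compound 2 to compound 3 (within the scatter). Compound 3 is therefore estimated at 30%, ranging from 10% to 55%.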

Compound 3, a percentage reported as inhibition, at one concentration (the size of the read-out at that concentration, not a potency): 23%
The estimate for compound 3 lay 7 percentage points above the measured number; the range from low to high includes it.
By their numbers in this assay, from the lowest: compounds 1, 3 and 2 (each within the scatter of the next).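

In this assay, dimethylamino in place of hydrogen on an aromatic carbon para to a large group gives a number 7 percentage points lower from compound 2 to compound 3 (within the scatter). Going by these compounds alone, this is the first view of a substituent at this position, and a group of 3 heavy atoms with no ring leaves the number within the usual scatter of the unsubstituted compound. Nothing available explains this result.

Still open, from the compounds shown here alone, is whether a carboxylic acid or a longer chain at this same place would move the number beyond the scatter. Going by these compounds, it is also open whether a smaller group, such as methoxy, would behave like dimethylamino here.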